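The source may report more compounds than this note shows. Statements on the series, on what has been measured and on what is new or still open speak of the compounds shown alone.

Measured so far in a functional assay on PC-3 cells (Homo sapiens) for antiproliferative activity, read by sulforhodamine B assay, with a stated time of 3 days; a lower number here means that less compound is needed, a higher number that more compound is needed for the effect:
compound 1 `CCCC1=C(OCC(C)C)C(CCC)(CCC)C(=O)/C(=C(O)\C=C\c2ccccc2)C1=O`: 12.2 uM
compound 2 `CCCCOC1=C(CCC)C(=O)/C(=C(O)/C=C/c2ccccc2)C(=O)C1(CCC)CCC`: 9.6 uM

Compound 2 carries the lower of the two numbers, but compound 1 stands within the scatter of it, so the two are not separated. Compound 3 `CCCC1=C(OCC)C(CCC)(CCC)C(=O)/C(=C(O)\C=C\c2ccccc2)C1=O` differs from compound 2 by hydrogen in place of ethyl on a saturated chain carbon, two bonds along the chain from an oxygen on an unsaturated carbon. Within the data shown here, the one measured step touching the same alkoxy chain is a 1.3-fold lower number from compound 1 to compound 2 (0.10 log units; within the scatter), which did not move the number beyond the scatter. No step beyond the scatter is therefore expected in this assay. Compound 3 is estimated at 10.5 uM, with a range of 5 uM to 22 uM. This estimate corresponds to an expected step of a 1.1-fold higher number from compound 2 to compound 3 (0.04 log units; within the scatter).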

Compound 3, concentration for half-maximal effect: 12.5 uM
The estimate for compound 3 lay 1.2-fold (0.08 log units) below the measured number; the range from low to high includes it.
By their numbers in this assay, from the lowest: compounds 2, 1 and 3 (each within the scatter of the next).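

In this assay the cut from butoxy to ethoxy gives a 1.3-fold higher number from compound 2 to compound 3 (0.11 log units; within the scatter) and methyl in place of isopropyl on the saturated chain carbon bound to an oxygen on an unsaturated carbon gives a 1.0-fold higher number from compound 1 to compound 3 (0.01 log units; within the scatter) so neither the shorter chain nor the loss of the branch separates these compounds. The three alkoxy chains shown therefore stand within the scatter of one another at this position. No measurement shown bears on the reason for this.

Still open, from the compounds shown here alone, is whether an alkoxy chain longer than butoxy, or one ending in an amine or a carboxylic acid, would move the number beyond the scatter.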